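Working notes: ethoxy for methyl on the shared core

The source may report more compounds than this note shows. Statements on the series, on what has been measured and on what is new or still open speak of the compounds shown alone.

Measured compounds:
compound 1, `Cc1ccc2nc(C(=O)Nc3c(F)cc(-c4cccc(F)c4)cc3F)c(C)c(O)c2c1`, with 11.2%
compound 2, `Cc1ccc2nc(C(=O)Nc3c(F)cc(-c4cccc(F)c4)cc3F)c(C)c(C(=O)O)c2c1`, with 21.3%

In a functional assay on Hep 3B2 cells (Homo sapiens) for antiproliferative activity, read by MTT assay, with a stated time of 24 h, tested at 1.23 ug/mL (on this read-out lower numbers stand for a weaker effect and higher numbers for a stronger effect at the one concentration tested), compound 1 gives 11.2%, while compound 2 gives 21.3%. For the measured compounds named here, the one measured step in the pair is a number 10.1 percentage points higher from compound 1 to compound 2 (beyond the scatter), which places compound 2 as the higher of the two numbers, the only other number lying beyond the scatter below it.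

Compound 3, `CCOc1ccc2nc(C(=O)Nc3c(F)cc(-c4cccc(F)c4)cc3F)c(C)c(C(=O)O)c2c1`, differs from compound 2 by ethoxy in place of methyl on an aromatic carbon. Going by the values given here, none of the measured steps bears on this change: the single step concerns the carboxy for hydroxy exchange, and compound 3 keeps the carboxy of compound 2. Among the compounds with values here, with no step on this position to lean on, no step beyond the scatter is expected, so the expected step is a number 0.3 percentage points lower from compound 2 to compound 3 (within the scatter). Compound 3 is accordingly estimated at 21%, with a range from 8% to 36%, to be checked against the measurement in this assay.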

Compound 3, a percentage reported as inhibition, at one concentration (the size of the read-out at that concentration, not a potency): 17.9%
Compound 3: middle estimate off by 3.1 percentage points, on the high side; the range from low to high includes it.
By their numbers in this assay, from the lowest: compounds 1, 3 and 2 (each within the scatter of the next, the first and the last beyond it).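

In this assay, ethoxy in place of methyl on this aromatic carbon of the shared core gives a number 3.4 percentage points lower from compound 2 to compound 3 (within the scatter), so within this carboxy-bearing pair the exchange does not move the read-out beyond the scatter. For the compounds shown here, the only earlier step concerned the carboxy for hydroxy exchange at another place, so this is the first reading of any change at this position, and here the position accepts ethoxy with its added oxygen at the one concentration tested. No supporting data are available to explain this result.

Open, going by these compounds, is whether the position stays this flat for other groups, such as an amine, a chlorine atom or a longer alkoxy chain like butoxy. Also open, on these data alone, is whether ethoxy in place of methyl reads the same when hydroxy replaces the carboxy, and whether the pair would separate across a range of concentrations.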